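The source may hold more compounds than are shown below. What is called first, only, known or untested is meant among the compounds shown, and "the series" means these compounds.

Series notes. Compound 1 `O=C(N/N=C/c1ccc(O)cc1)Nc1ccc(Oc2ccnc3[nH]ccc23)c(F)c1` gives 2780 nM in a functional assay on PC-3 cells (Homo sapiens) for antiproliferative activity, read by MTT assay, with a stated time of 72 h; on this read-out lower numbers stand for stronger inhibition and higher numbers for weaker inhibition. Compound 2 `COc1ccc(/C=N/NC(=O)Nc2ccc(Oc3ccnc4[nH]ccc34)c(F)c2)cc1` carries the change methyl in place of hydrogen on an oxygen on an aromatic ring and in this assay compound 2 gives 6730 nM, a step of a 2.4-fold higher number from compound 1 to compound 2 (0.38 log units; beyond the scatter). Compound 3 `O=C(N/N=C/c1ccc(O)cc1)Nc1ccc(Oc2ccnc3[nH]ccc23)cc1` differs from compound 1 by hydrogen in place of fluoro on an aromatic carbon; in this assay compound 3 gives 4920 nM, a step of a 1.8-fold higher number from compound 1 to compound 3 (0.25 log units; within the scatter).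

Compound 4 `COc1ccc(/C=N/NC(=O)Nc2ccc(Oc3ccnc4[nH]ccc34)cc2)cc1` is not yet measured. It relates to compound 3 by methyl in place of hydrogen on an oxygen on an aromatic ring, the same change that took compound 1 to compound 2, made on the core of compound 3 rather than that of compound 1; the cores differ by hydrogen in place of fluoro on an aromatic carbon.

Because a 2.4-fold higher number from compound 1 to compound 2 (0.38 log units; beyond the scatter) was seen for this change on the other core, a similar step is expected here, estimated as a 2.2-fold higher number from compound 3 to compound 4 (0.35 log units; beyond the scatter). Compound 4 is therefore expected to give about 11000 nM, within 5000 nM to 25000 nM.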

Compound 4, half-maximal inhibitory concentration: "not active" (no number reported)
Nothing numeric was reported for compound 4; no gap can be computed for the estimate.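

Within the data shown here, compound 4 is recorded as "not active" with no number, so no step from compound 3 to compound 4 can be read. How far the hydroxy to methoxy change raises the number on this core stays open, and nothing shown explains the result.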